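A few compounds are considered here, and "the series" means these few. Any claim that something is new, unique, unknown or untested is made for them only; others in the source may bear on it.

Measured compounds in a functional assay on SW480 cells (Homo sapiens) for cytotoxicity, read by MTT assay, with a stated time of 4 days; a lower number here means a stronger inhibitor, a higher number a weaker inhibitor:
Compound 1, `Cc1ccc(S(=O)(=O)Oc2ccc3c(c2C)[C@H](Cn2cc(-c4ccccn4)nn2)[C@@]24CC(=O)[C@@](C)(CC[C@@H]32)C4)cc1`, gives > 20000 nM, which is a limit of the assay.
Compound 2, `Cc1ccc(-c2cn(C[C@H]3c4c(ccc(O)c4C)[C@@H]4CC[C@@]5(C)C[C@]43CC5=O)nn2)cc1`, gives > 20000 nM, which is also a limit of the assay.

Among the compounds with values here, compound 2 therefore stands at the ceiling of what this assay reports: its value is a limit rather than a number, and the only other value shown is a limit as well (the limit of > 20000 nM in this assay, at which 2 of the 2 values shown sit). Compound 3, `Cc1ccc(-c2cn(C[C@H]3c4c(ccc(OS(=O)(=O)c5ccc(C)cc5)c4C)[C@@H]4CC[C@@]5(C)C[C@]43CC5=O)nn2)cc1`, differs from compound 2 by (4-methylphenyl)sulfonyl in place of hydrogen on an oxygen on an aromatic ring. Within the data shown here, no step between measured compounds covers this change. Compound 1 carries the same (4-methylphenyl)sulfonyl on its oxygen and also sits at the limit, which gives no sign that the group brings potency. Compound 3 is thus expected to stay at or beyond the limit, with no step beyond the scatter, the expected step being a step that the limit leaves unreadable from compound 2 to compound 3. The estimate for compound 3 in this assay is 30000 nM, expected between 10000 nM and 100000 nM.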

Compound 3, half-maximal inhibitory concentration: > 20000 nM
Compound 3: no number, only a limit; the forecaster's own chance of this, stated with the estimate: 85%; the middle value lies beyond the limit too.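

Within the data shown here, compound 3 sits at the same limit as compound 1 and compound 2 in this assay, so no step from either compound to compound 3 can be read: the limit of > 20000 nM in this assay, at which 3 of the 3 values shown sit. The compounds shown leave open how far beyond that limit each lies, and so whether (4-methylphenyl)sulfonyl in place of hydrogen, or 4-methylphenyl in place of pyridin-2-yl, changes anything.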